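The source may report more compounds than this note shows. Statements on the series, on what has been measured and on what is new or still open speak of the compounds shown alone.

Measured compounds:
Compound 1 `CN(c1ccn(C)n1)c1cnc(NCc2c(F)ccc3c2CCO3)c2cn[nH]c(=O)c12` — in an ADME assay on microsomes from liver (Homo sapiens) for metabolic stability, read by LC-MS, using NADPH, with stated times of 5 min and 30 min, tested at 1 uM (on this read-out higher numbers stand for fast clearance and lower numbers for slow clearance), compound 1 gives 62 mL.min-1.g-1.
Compound 2 `O=C1CCCN1c1cnc(NCc2c(F)ccc3c2CCO3)c2cn[nH]c(=O)c12` — compound 2 gives 23 mL.min-1.g-1.
Compound 3 `Cc1nc(C(=O)N(C)C)ccc1-c1cnc(NCc2c(F)ccc3c2CCO3)c2cn[nH]c(=O)c12` — compound 3 gives 19 mL.min-1.g-1.

Of the three numbers, compound 3 gives the lowest; the gap to compound 2 lies within the usual scatter, so the two cannot be separated, while the gap to compound 1 lies beyond the scatter. Within the data shown here, the one single-point step among the measured compounds, a 2.7-fold lower number from compound 1 to compound 2 (0.43 log units; beyond the scatter), concerns a change on the shared core and not the ring carried by compound 3.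

Compound 4 `Cc1nc(CO)ccc1-c1cnc(NCc2c(F)ccc3c2CCO3)c2cn[nH]c(=O)c12` differs from compound 3 in one place: hydroxymethyl in place of dimethylcarbamoyl on an aromatic carbon. Among the measured compounds shown here, no measured step touches this group or this position, so nothing in the data speaks directly to the change. For the measured compounds named here, the only guidance is that the three measured values span a modest spread, and that compound 2 and compound 3 sit within the scatter of each other despite carrying quite different groups. On that footing the expectation is for no step beyond the scatter, with the estimated change no change at the digits printed from compound 3 to compound 4 (within the scatter). Compound 4 is therefore expected to give about 19 mL.min-1.g-1, between 9 mL.min-1.g-1 and 40 mL.min-1.g-1, in this assay.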

Compound 4, intrinsic clearance in microsomes in the Homo sapiens assay: 11 mL.min-1.g-1
Estimate against measurement, compound 4: 1.7-fold (0.24 log units) above; measured number inside the range.
By their numbers in the Homo sapiens assay, from the lowest: compounds 4, 3 and 2 (each within the scatter of the next, the first and the last beyond it); then compound 1.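

In the Homo sapiens assay, hydroxymethyl in place of dimethylcarbamoyl, on the aromatic carbon next to the ring nitrogen, gives a 1.7-fold lower number from compound 3 to compound 4 (0.24 log units; within the scatter), so this first change at this position cannot be told apart from no change on this read-out, although the group that enters is much smaller and carries a hydrogen-bond donor. The 6-(hydroxymethyl)-2-methylpyridin-3-yl group on the shared core does stand apart from the other two groups, with a 2.1-fold lower number from compound 2 to compound 4 (0.32 log units; beyond the scatter) and a 5.6-fold lower number from compound 1 to compound 4 (0.75 log units; beyond the scatter), whereas compound 3 stayed within the scatter of compound 2. In a physicochemical assay for lipophilicity, using the shake flask method, in phosphate buffer, measured as octanol-water partition, with a stated time of 30 min, at pH 7.4 (on this read-out higher numbers stand for higher lipophilicity and lower numbers for lower lipophilicity), compound 3 gives 2.1 and compound 4 gives 2.4, which is a number 0.30 log units higher from compound 3 to compound 4 (within the scatter), so neither read-out separates this pair.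

No measurement shown accounts for any of these numbers. On these data alone, it remains open how a carboxylic acid, an aminomethyl group or a longer chain such as hydroxyethyl at this carbon would read in these assays, and whether the methyl group meta to this position contributes to the numbers at all.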